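A Chain in Place of 4-Nitrophenyl at the Limit

The source may report more compounds than this note shows. Statements on the series, on what has been measured and on what is new or still open speak of the compounds shown alone.

In a functional assay on RAW264.7 cells (Mus musculus) for inhibition, read by Griess assay, with stated times of 3 h and 24 h (a higher number here means a weaker inhibitor, a lower number a stronger inhibitor), compound 1 `C=C1CC[C@H]2[C@@](C)(CC[C@@H](O)[C@@]2(C)NC=O)[C@@H]1/C=C/C1=CCOC1=O` reports > 50000 nM, which is a limit and not a number. Compound 2 `C=C1CC[C@H]2[C@@](C)(CC[C@@H](OC(=O)c3ccccc3)[C@@]2(C)NC=O)[C@@H]1/C=C/C1=CCOC1=O` gives 50000 nM in this assay. Compound 3 `C=C1CC[C@H]2[C@@](C)(CC[C@@H](OC(=O)c3ccc([N+](=O)[O-])cc3)[C@@]2(C)NC=O)[C@@H]1/C=C/C1=CCOC1=O` also reports only a limit, > 50000 nM, so its true position is not known.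

Compound 4 `C=C1CC[C@H]2[C@@](C)(CC[C@@H](OC(=O)[C@H](N)CC(C)C)[C@@]2(C)NC=O)[C@@H]1/C=C/C1=CCOC1=O` carries 1-amino-3-methylbutyl in place of 4-nitrophenyl on a carbonyl carbon.

Within the data shown here, three measured steps bear on this change, and none has a readable size. Benzoyl on the oxygen gave a number no higher from compound 1 to compound 2 (the limit leaves the size open). (4-Nitrophenyl)carbonyl on the oxygen gave a step that the two limits leave unreadable from compound 1 to compound 3. Nitro on the aromatic carbon gave a number no lower from compound 2 to compound 3 (the limit leaves the size open). Among the measured compounds shown here, no measured step places an amino-bearing chain on this carbonyl, so the expectation rests on compound 2 with 50000 nM as the only number available. A modest move towards stronger inhibition is expected, estimated as an at least 1.6-fold lower number from compound 3 to compound 4 (0.22 log units; that floor lies within the scatter). For compound 4 the estimated value is 30000 nM, with an expected range from 8000 nM to 50000 nM.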

Compound 4, half-maximal inhibitory concentration: > 50000 nM
Compound 4: no number, only a limit; the forecaster's own chance of this, stated with the estimate: 45%; at least 1.6-fold (0.22 log units) between middle value and limit.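

With 1-amino-3-methylbutyl on the carbonyl carbon, compound 4 still gives no number in this assay, so this amino-bearing chain, like 4-nitrophenyl, leaves the position without a measured value. The only direction available is a number no lower from compound 2 to compound 4 (the limit leaves the size open); the steps from compound 1 and from compound 3 to compound 4 cannot be read. The set therefore remains largely unordered: the limit of > 50000 nM in this assay, at which 3 of the 4 values shown sit.

Among these compounds, compound 2, at 50000 nM, remains the only number, and it is still open whether any other group on this carbonyl carbon would give a value clearly apart from it in this assay. As far as these compounds go, it is also open what a longer chain without the amine, or a chain ending in a carboxylic acid, would read at this position.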